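This account rests on a few compounds, and the source may have more. Where it says the series, first, only, none or still open, it means among the compounds named here.

Compound 1 `O=C(O)[C@@H]1NC[C@@H](O)[C@@H](O)[C@H]1O` and compound 2 `O=C(O)[C@@H]1NC[C@H](O)[C@@H](O)[C@@H]1O` share every atom and bond and differ only in configuration as drawn. In an assay for inhibition of alpha-N-acetylgalactosaminidase (Gallus gallus), tested at 1000 uM (a higher number here means more inhibition at the concentration tested (going by the name of the read-out), a lower number less inhibition), compound 1 gives 8.2%, and compound 2 gives 3.4%. The step of a number 4.8 percentage points lower from compound 1 to compound 2 (within the scatter) leaves compound 2 with the lower of the two numbers, yet the two values lie within the scatter of each other, so neither compound is called the stronger. Compound 3 `O=C(O)[C@@H]1NC[C@H](O)[C@H](O)[C@H]1O` follows from compound 2 by a further change in configuration only: the two compounds have the same atoms and bonds and differ only in configuration as drawn: 2 of 4 stereo elements differ; a stereocentre at a saturated ring carbon is drawn R in compound 2 and S in compound 3; a stereocentre at a saturated ring carbon is drawn R in compound 2 and S in compound 3. Among the measured compounds shown here, only one measured step bears on this change, and that step, a number 4.8 percentage points lower from compound 1 to compound 2 (within the scatter), moved the reading by no more than the scatter. A step of the same kind is expected here, and the expected step is a number 3.6 percentage points higher from compound 2 to compound 3 (within the scatter), with no direction beyond the scatter. Compound 3 is therefore estimated at 7%, in the range -5% to 30%.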

Compound 3, a percentage reported as inhibition, at one concentration (the size of the read-out at that concentration, not a potency): 4.4%
Beside the measured number, compound 3's estimate is 2.6 percentage points above it; measured number inside the range.
By their numbers in this assay, from the lowest: compounds 2, 3 and 1 (each within the scatter of the next).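

In this assay, the further change of two stereocentres gives a number 1 percentage points higher from compound 2 to compound 3 (within the scatter), and the pair not compared before gives a number 3.8 percentage points lower from compound 1 to compound 3 (within the scatter). Every pair among the three compounds now lies within the scatter, so where compound 1 and compound 2 offered a single such comparison, three different swaps of two stereocentres now fail to separate the readings, and no order can be set among these compounds. The new comparisons rest on configuration alone: the fact that compounds 2 and 3 differ only in the configuration as drawn

The compounds shown leave open whether any other arrangement of the stereocentres on the shared core would move the reading in this assay beyond the scatter. They also leave open what a methyl ester or an amide in place of the carboxylic acid, or a longer chain on the nitrogen, would do.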